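Swapping tert-butyl for 1-methylpiperidin-4-yl in compound 3

The source may report more compounds than this note shows. Statements on the series, on what has been measured and on what is new or still open speak of the compounds shown alone.

compound 1 `CN1CCC(C(=O)N2Cc3c(NC(=O)c4ccc5ccccc5c4)n[nH]c3C2(C)C)CC1` gives 219000 nM
compound 2 `CN1CCC(C(=O)N2Cc3c(NC(=O)c4ccc(C(F)(F)F)cc4)n[nH]c3C2(C)C)CC1` gives 191000 nM
compound 3 `CC(C)(C)C(=O)N1Cc2c(NC(=O)c3ccncc3)n[nH]c2C1(C)C` gives 205000 nM

In a physicochemical assay for solubility, at pH 7 (on this read-out lower numbers stand for lower solubility and higher numbers for higher solubility), compound 3 stands at 205000 nM and lies within the usual scatter of both other compounds, so the three numbers cannot be ranked.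

Compound 4 `CN1CCC(C(=O)N2Cc3c(NC(=O)c4ccncc4)n[nH]c3C2(C)C)CC1` differs from compound 3 in one place: 1-methylpiperidin-4-yl sits in place of tert-butyl on a carbonyl carbon 1-methylpiperidin-4-yl in place of tert-butyl on a carbonyl carbon and the rest of the molecule stays the same.

Within the data shown here, no measured step makes this exchange directly. Among the measured compounds shown here, the only step available is a 1.1-fold lower number from compound 1 to compound 2 (0.06 log units; within the scatter) and it stays within the scatter, but it concerns a different group, 4-(trifluoromethyl)phenyl in place of naphthalen-2-yl. Indirect evidence comes from the compounds that already carry 1-methylpiperidin-4-yl. Compound 1 at 219000 nM and compound 2 at 191000 nM show numbers within the scatter of compound 3 at 205000 nM with its tert-butyl, although their other group differs too.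

No change beyond the scatter is therefore expected in this assay in either direction. The expected step is no change at the digits printed from compound 3 to compound 4 (within the scatter) and this remains an estimate. For compound 4 205000 nM is the estimated value, with 120000 nM to 320000 nM as the expected range.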

Compound 4, solubility: > 225000 nM
Compound 4 was reported as a limit; the forecaster's own chance of this, stated with the estimate: 10%; middle value at least 1.0-fold (0.04 log units) away from the limit.
By their numbers in this assay, from the lowest: compounds 2, 3 and 1 (each within the scatter of the next). At a limit, above all of these: compound 4.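

In this assay, compound 4 is reported only as a limit and not as a number: the limit of > 225000 nM in this assay, at which 1 of the 4 values shown sits. The exchange of tert-butyl for 1-methylpiperidin-4-yl on a carbonyl carbon can now be read directly, as an at least 1.0-fold higher number from compound 3 to compound 4 (0.04 log units; that floor lies within the scatter), so a fall on this read-out is ruled out, while a real rise is not established. With 1-methylpiperidin-4-yl held fixed, pyridin-4-yl in place of 4-(trifluoromethyl)phenyl comes out as an at least 1.1-fold higher number from compound 2 to compound 4 (0.07 log units; that floor lies within the scatter), and pyridin-4-yl in place of naphthalen-2-yl comes out as an at least 1.0-fold higher number from compound 1 to compound 4 (0.01 log units; that floor lies within the scatter), so neither exchange lowers the number, but neither floor shows a change beyond the scatter.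

From the compounds shown here alone, how far compound 4 truly lies past its limit stays open, so the full size of all three steps is unknown. Also open, going by these compounds, is whether an open-chain amine or a carboxylic acid on the same carbonyl carbon would match 1-methylpiperidin-4-yl, and whether the exchange from tert-butyl would read the same with naphthalen-2-yl or 4-(trifluoromethyl)phenyl in place of pyridin-4-yl.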